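Methyl for Hydrogen on a Carbonyl in a Weak Antiproliferative Series

The source may hold more compounds than are shown below. What is called first, only, known or untested is meant among the compounds shown, and "the series" means these compounds.

Measured so far:
compound 1 `CC(=O)N1CCN(C=O)C1=S` — > 100000 nM
compound 2 `O=C(c1ccc(Cl)c(Cl)c1)N1CCCN(C(=O)c2ccc(Cl)c(Cl)c2)C1=S` — 72000 nM

Of the compounds shown here, two have been tested in a functional assay on MT4 cells (Homo sapiens) for antiproliferative activity, read by MTT assay; on this read-out higher numbers stand for weaker inhibition and lower numbers for stronger inhibition. For compound 1 the result is only a limit of the assay, > 100000 nM, with no number behind it, as noted in the limit of > 100000 nM in this assay, at which 1 of the 2 values shown sits. The other measured compound is a larger molecule that shares no single-point relation with compound 1; in this assay compound 2 gives 72000 nM. Going by the values given here, no step between the two measured compounds is available, so their values are simply reported side by side.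

The next compound, compound 3 `CC(=O)N1CCN(C(C)=O)C1=S`, differs from compound 1 by methyl in place of hydrogen on a carbonyl carbon, which reads as formyl to acetyl. For this small change the expected step that the limit leaves unreadable from compound 1 to compound 3 is none beyond the usual scatter, since compound 1 itself shows only the limit > 100000 nM. Compound 3 is therefore estimated at 150000 nM, within a range from 50000 nM to 500000 nM, and most likely the assay will again report only a limit.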

Compound 3, half-maximal inhibitory concentration: > 100000 nM
Compound 3 gave a limit, no number; the forecaster's own chance of this, stated with the estimate: 80%; the middle value does not contradict the limit.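

Compound 1 and compound 3 both give only a limit, not a number, so no step can be read between them: the limit of > 100000 nM in this assay, at which 2 of the 3 values shown sit. The compounds shown leave open whether methyl in place of hydrogen on a carbonyl carbon changes the result in this assay at all.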